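Notes on a nucleoside series: methoxy to methylamino

This account rests on a few compounds, and the source may have more. Where it says the series, first, only, none or still open, it means among the compounds named here.

Within the data shown here, compound 3 `COc1ncnc2c1c(-c1cc3ccccc3o1)cn2[C@@H]1O[C@H](CO)[C@@H](O)[C@H]1O` is the only member with a number in a functional assay on K562 cells (Homo sapiens), read by MTT assay, with a stated time of 72 h; on this read-out higher numbers stand for weaker inhibition and lower numbers for stronger inhibition; in that assay compound 3 gives 20900 nM. Compound 1 `C#Cc1cn([C@@H]2O[C@H](CO)[C@@H](O)[C@H]2O)c2ncnc(NC)c12` reaches only a limit of the assay in this assay, at > 20000 nM. Compound 2 `CNc1ncnc2c1c(-c1cccs1)cn2[C@@H]1O[C@H](CO)[C@@H](O)[C@H]1O` likewise sits at a limit in this assay, > 20000 nM. The step that the two limits leave unreadable from compound 1 to compound 2 therefore cannot be sized. Taken together, the limit of > 20000 nM in this assay, at which 2 of the 3 values shown sit, places the series at the weak end of the measured range, and compound 3 stands within the usual scatter of that limit rather than apart from it.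

Compound 4 `CNc1ncnc2c1c(-c1cc3ccccc3o1)cn2[C@@H]1O[C@H](CO)[C@@H](O)[C@H]1O` is compound 3 with methylamino in place of methoxy on an aromatic carbon. Among the measured compounds shown here, no measured step exchanges these two groups; the only measured step, from compound 1 to compound 2, alters a different position and is unreadable. Compounds 1 and 2 also carry methylamino, and neither yields a number. No step beyond the scatter is expected. The step of a 1.0-fold lower number from compound 3 to compound 4 (0.02 log units; within the scatter) is expected to stay within the scatter. Compound 4 is estimated at 20000 nM, with a range from 8000 nM to 50000 nM. A limit rather than a number is considered likely for compound 4.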

Compound 4, half-maximal inhibitory concentration: > 20000 nM
Compound 4 was reported as a limit; the forecaster's own chance of this, stated with the estimate: 60%; the middle value sits exactly at the limit.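

In this assay compound 4 gives > 20000 nM, a limit of the assay and not a number, so the steps to it from compound 1, compound 2 and compound 3 cannot be read. The compounds shown leave open whether methylamino in place of methoxy, or any exchange among ethynyl, thiophen-2-yl and 1-benzofuran-2-yl, changes the read-out at all.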